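Lengthening the sulfur chain of a dithiocarbamate lactone

A few compounds are considered here, and "the series" means these few. Any claim that something is new, unique, unknown or untested is made for them only; others in the source may bear on it.

Measured compounds:
compound 1 `O=C(CSC(=S)N[C@H]1CCOC1=O)Nc1ccc(Br)cc1`, 67400 nM in a functional assay on EC9706 cells (Homo sapiens) for cytotoxicity, read by MTT assay, with a stated time of 72 h; on this read-out higher numbers stand for weaker inhibition and lower numbers for stronger inhibition
compound 2 `CSC(=S)N[C@H]1CCOC1=O`, > 128000 nM in this assay

Compound 2 stands at the weak end of the numbers shown. In this assay compound 2 gives only a limit, > 128000 nM, which is the edge of what the assay reports and not a number (the limit of > 128000 nM in this assay, at which 1 of the 2 values shown sits). Compound 3 `CCCCCCSC(=S)N[C@H]1CCOC1=O` differs from compound 2 by pentyl in place of hydrogen on a saturated chain carbon bound to a sulfur. Within the data shown here, no step between measured compounds is known, so the size of this step in this assay is open. Compound 3 is expected at 90000 nM, between 30000 nM and 200000 nM. The expected step is an at least 1.4-fold lower number from compound 2 to compound 3 (0.15 log units; that floor lies within the scatter).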

Compound 3, half-maximal inhibitory concentration: > 128000 nM
Compound 3 was reported as a limit; the forecaster's own chance of this, stated with the estimate: 45%; at least 1.4-fold (0.15 log units) between middle value and limit.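

Compound 2 and compound 3 both give only a limit, so no step can be read between them: the limit of > 128000 nM in this assay, at which 2 of the 3 values shown sit.

The compounds shown leave open whether pentyl in place of hydrogen changes the result in this assay at all, and by how much.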